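Working notes: from compound 3 to compound 4 in permeability

A few compounds are considered here, and "the series" means these few. Any claim that something is new, unique, unknown or untested is made for them only; others in the source may bear on it.

The series shares one core, carried by compound 1 `CC(C)OC(=O)NCCS(=O)(=O)NC(=O)c1ccc(Nc2nc(NC3(c4ccc(Cl)cc4)CC3)nc(OCC(F)(F)F)n2)cc1`, compound 2 `Cc1ccccc1S(=O)(=O)NC(=O)c1ccc(Nc2nc(NC3(c4ccc(Cl)cc4)CC3)nc(OCC(F)(F)F)n2)cc1` and compound 3 `CC(C)(C)OC(=O)NCCS(=O)(=O)NC(=O)c1ccc(Nc2nc(NC3(c4ccc(Cl)cc4)CC3)nc(OCC(F)(F)F)n2)cc1`. In a physicochemical assay for permeability, using PAMPA, at pH 7.4 (a higher number here means that the compound crosses the layer faster, a lower number that the compound crosses the layer more slowly), compound 1 gives 71 nm/s, compound 2 gives 265 nm/s and compound 3 gives 111 nm/s. Compound 3 therefore stands second highest of the three numbers: its nearest neighbour is compound 1, since a 1.6-fold higher number from compound 1 to compound 3 (0.19 log units; within the scatter), and its furthest is compound 2, since a 2.4-fold lower number from compound 2 to compound 3 (0.38 log units; beyond the scatter). The remaining pair is covered by a 3.7-fold higher number from compound 1 to compound 2 (0.57 log units; beyond the scatter).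

Compound 4 `CC(C)C(=O)NCCS(=O)(=O)NC(=O)c1ccc(Nc2nc(NC3(c4ccc(Cl)cc4)CC3)nc(OCC(F)(F)F)n2)cc1` has not yet been measured in this assay. It differs from compound 3 in one place: isopropyl in place of tert-butoxy on a carbonyl carbon. Among the measured compounds shown here, of the measured steps, only that from compound 1 to compound 3 touches the same part of the molecule, and there a 1.6-fold higher number from compound 1 to compound 3 (0.19 log units; within the scatter). The steps from compound 1 to compound 2 and from compound 2 to compound 3 each exchange the whole group on the sulfonyl sulfur, were of modest size, and bear on the present change only loosely. Accordingly, the change from compound 3 to compound 4 is expected to give no step beyond the scatter, if anything a slightly lower number. Compound 4 is therefore estimated at 85 nm/s in this assay, with a range from 40 nm/s to 180 nm/s. This estimate corresponds to an expected 1.3-fold lower number from compound 3 to compound 4 (0.12 log units; within the scatter).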

Compound 4, apparent permeability: 13 nm/s
The estimate for compound 4 lay 6.5-fold (0.82 log units) above the measured number; measured number below the stated range.
By their numbers in this assay, from the lowest: compound 4; then compounds 1 and 3 (each within the scatter of the next); then compound 2.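

In this assay, the carbonyl carbon on the amide-type nitrogen emerges as a sensitive position: isopropyl in place of tert-butoxy gives an 8.5-fold lower number from compound 3 to compound 4 (0.93 log units; beyond the scatter), whereas the earlier change in this part of the molecule, a 1.6-fold higher number from compound 1 to compound 3 (0.19 log units; within the scatter), stayed within the scatter. Isopropoxy and tert-butoxy therefore read alike here, and the same exchange from isopropoxy gives a 5.5-fold lower number from compound 1 to compound 4 (0.74 log units; beyond the scatter), so in both available comparisons isopropyl on this carbon gives the lower number. With this isopropyl group in the chain, the exchange on the sulfonyl sulfur now gives a 20-fold lower number from compound 2 to compound 4 (1.31 log units; beyond the scatter), the widest step in the series.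

No data at hand bear on why the number falls at this carbon. Going by these compounds, whether the fall follows the oxygen bound to the carbonyl carbon or the size of the group stays open, and a tert-butyl or an amine on this carbon would help separate the two.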